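The source may report more compounds than this note shows. Statements on the series, on what has been measured and on what is new or still open speak of the compounds shown alone.

Of the compounds shown here, three sharing one core have been measured. In a functional assay on CHO-K1 cells for antagonist activity at C-X-C chemokine receptor type 3 (Homo sapiens), read by FLIPR, with a stated time of 10 min, in the presence of a further agent that is not named here (a higher number here means a weaker inhibitor, a lower number a stronger inhibitor), compound 1 `C[C@@H]1CN(c2sc(C(F)(F)F)nc2-c2nc3ccccc3[nH]2)CCN1C(=O)Cn1ccc(C(=O)O)n1` gives 2100 nM. Compound 2 `Cc1nn(CC(=O)N2CCN(c3sc(C(F)(F)F)nc3-c3nc4ccccc4[nH]3)C[C@H]2C)cc1CN(C)C` gives 2.7 nM, and compound 3 `C[C@@H]1CN(c2sc(C(F)(F)F)nc2-c2nc3ccccc3[nH]2)CCN1C(=O)Cn1cnc2c1CCN(C)C2` gives 3.6 nM. Compound 3 thus stands next to compound 2, the pair lying within the scatter (a 1.3-fold higher number from compound 2 to compound 3 (0.12 log units; within the scatter)), while both sit far from compound 1 (a 580-fold lower number from compound 1 to compound 3 (2.77 log units; beyond the scatter)). Compound 4 `C[C@@H]1CN(c2sc(C(F)(F)F)nc2-c2nc3ccccc3[nH]2)CCN1C(=O)Cn1cc(C2CCN(C)CC2)cn1` differs from compound 3 in one place: a group of 12 heavy atoms (9 carbon, 3 nitrogen; one five-membered aromatic ring with 2 hetero atoms, one six-membered non-aromatic ring with 1 hetero atom) in place of a group of 10 heavy atoms (7 carbon, 3 nitrogen; one five-membered aromatic ring with 2 hetero atoms, one six-membered non-aromatic ring with 1 hetero atom), on a saturated chain carbon bound to a carbonyl carbon. The large step from compound 1 to compound 3 replaced a carboxy-bearing group, which is not at issue here. Because a 1.3-fold higher number from compound 2 to compound 3 (0.12 log units; within the scatter) stayed within the scatter when two groups of similar make-up were exchanged at this place, the expected step is a 1.4-fold higher number from compound 3 to compound 4 (0.14 log units; within the scatter). Compound 4 is therefore estimated at 5 nM, between 1.5 nM and 20 nM.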

Compound 4, half-maximal inhibitory concentration: 15 nM
Compound 4: middle estimate off by 3.0-fold (0.48 log units), on the low side; low and high end bracket the measured number.
By their numbers in this assay, from the lowest: compounds 2 and 3 (each within the scatter of the next); then compound 4; then compound 1.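

In this assay, exchanging one amine-bearing group for another at this place is not always neutral: a 4.2-fold higher number from compound 3 to compound 4 (0.62 log units; beyond the scatter) and a 5.6-fold higher number from compound 2 to compound 4 (0.74 log units; beyond the scatter) both lie beyond the scatter, though both are modest. The 4-(1-methylpiperidin-4-yl)-1H-pyrazol-1-yl group still retains a large advantage over the carboxy-bearing group, with a 140-fold lower number from compound 1 to compound 4 (2.15 log units; beyond the scatter). Nothing measured here explains the modest loss. From the compounds shown here alone, it remains open how much the ring amine contributes. A 4-(piperidin-4-yl)-1H-pyrazol-1-yl group, without the methyl, or a 4-(tetrahydropyran-4-yl)-1H-pyrazol-1-yl group, with oxygen replacing that ring nitrogen, would test this.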